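Swapping the Aryl Ether Cap on a Weakly Cytotoxic Glycoside

The compounds below may be only part of what the source reports. "The series", "measured", "known", "first", "only" and "open" are said of these compounds alone.

The series is built around a shared sugar core carrying two aryl ether arms. In a functional assay on MDA-MB-231 cells (Homo sapiens) for cytotoxicity, read by MTT assay, with a stated time of 48 h (on this read-out higher numbers stand for an effect only at larger amounts of compound and lower numbers for an effect already at smaller amounts), compound 1 `CO[C@H]1O[C@H](COc2cccc3c2CCCC3)[C@@H](O)[C@H](O)[C@H]1Oc1ccc(OC2CCCCC2)cc1` gives "not determined" (no result reported), and in this assay compound 3 `CO[C@@H]1O[C@H](COc2ccc3c(c2)CCCC3)[C@@H](O)[C@H](O)[C@H]1Oc1ccc(OC2CCCCC2)cc1` gives "not determined" (no result reported), so neither carries a number. Among the measured compounds shown here, the single value in the set belongs to compound 2 `CO[C@H]1O[C@H](COc2ccc3c(c2)CCCC3)[C@@H](O)[C@H](O)[C@H]1Oc1ccc(OC2CCCCC2)cc1`, which in this assay gives 20000 nM. It is worth noting that (the fact that compounds 2 and 3 differ only in the configuration as drawn), so compound 3 is the configurational partner of compound 2, without a result of its own to compare. Compound 2 therefore stands alone on the numbers shown, with an effect appearing only at large amounts.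

The new entry, compound 4 `CO[C@H]1O[C@H](COc2ccccc2C(C)C)[C@@H](O)[C@H](O)[C@H]1Oc1ccc(OC2CCCCC2)cc1`, departs from compound 2 by one change: 2-isopropylphenyl in place of 1,2,3,4-tetrahydronaphthalen-6-yl on an oxygen on a saturated carbon. Both groups are carbon-only aromatic ether caps of similar size with no donors or acceptors, so no step beyond the usual scatter is expected from compound 2 to compound 4 in this assay, in either direction. The change is estimated as no change at the digits printed from compound 2 to compound 4 (within the scatter). Compound 4 is accordingly expected to give 20000 nM in this assay, with a plausible range from 8000 nM to 50000 nM.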

Compound 4, half-maximal effective concentration: 36000 nM
Compound 4: middle estimate off by 1.8-fold (0.26 log units), on the low side; low and high end bracket the measured number.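

In this assay, replacing 1,2,3,4-tetrahydronaphthalen-6-yl with 2-isopropylphenyl on this oxygen gives a 1.8-fold higher number from compound 2 to compound 4 (0.26 log units; within the scatter), so the two compounds cannot be told apart on this read-out. Among the compounds shown here, this is the first pair with a number on both sides, and it shows that the non-aromatic ring of compound 2 can be absent, as in compound 4, with the effect still appearing only at large amounts of compound. Nothing given here bears on why the two caps read alike.

As far as these compounds go, it remains open whether a cap carrying an amine or a carboxylic acid at this position would move the number beyond the scatter. From the compounds shown here alone, the effect of the configuration as drawn also remains open, as compound 3 has no number to set against compound 2.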